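Aryl amide swap on the shared core

This account rests on a few compounds, and the source may have more. Where it says the series, first, only, none or still open, it means among the compounds named here.

Measured so far:
- compound 1 `Cc1nc(C(=O)Nc2ccc(Cl)c(-c3nnc4c(Cl)cccn34)c2)cs1` — 79800 nM
- compound 2 `O=C(Nc1ccc(Cl)c(-c2nnc3c(Cl)cccn23)c1)c1cccc(Cl)c1` — assay limit only, > 100000 nM

Within the data shown here, in a functional assay on HeLa cells (Homo sapiens) for antiproliferative activity, read by MTT assay, with a stated time of 72 h (on this read-out lower numbers stand for stronger inhibition and higher numbers for weaker inhibition), compound 1 holds the only actual number of the pair; compound 2 reports a limit of the assay rather than a number. Among the measured compounds shown here, the single measured step, an at least 1.2-fold higher number from compound 1 to compound 2 (0.09 log units; that floor lies within the scatter), is therefore only a floor, and that floor rests on (the limit of > 100000 nM in this assay, at which 1 of the 2 values shown sits).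

Compound 3 `O=C(Nc1ccc(Cl)c(-c2nnc3c(Cl)cccn23)c1)c1cccnc1Cl` differs from compound 1 by 2-chloropyridin-3-yl in place of 2-methyl-1,3-thiazol-4-yl on a carbonyl carbon. This resembles the measured step in kind: a chlorine-bearing six-membered aromatic ring takes the place of the 2-methyl-1,3-thiazol-4-yl group on the carbonyl carbon, and that earlier step gave an at least 1.2-fold higher number from compound 1 to compound 2 (0.09 log units; that floor lies within the scatter). Compound 3 is therefore expected to move in the same direction, by about a 1.3-fold higher number from compound 1 to compound 3 (0.10 log units; within the scatter), with a real chance that only a limit is reported. The estimate for compound 3 is 100000 nM, expected between 40000 nM and 250000 nM.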

Compound 3, half-maximal inhibitory concentration: 87500 nM
Beside the measured number, compound 3's estimate is 1.1-fold (0.06 log units) above it, and the stated range covers the measured number.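

In this assay, 2-chloropyridin-3-yl in place of 2-methyl-1,3-thiazol-4-yl gives a 1.1-fold higher number from compound 1 to compound 3 (0.04 log units; within the scatter), so a six-membered and a five-membered aromatic ring on this carbonyl carbon now stand as two real numbers that cannot be told apart. The other comparison with a six-membered ring, an at least 1.1-fold lower number from compound 2 to compound 3 (0.05 log units; that floor lies within the scatter), gives only a floor and sets no order between the 3-chlorophenyl and 2-chloropyridin-3-yl groups. Compound 2 carries a limit of the assay, not a number: the limit of > 100000 nM in this assay, at which 1 of the 3 values shown sits.

Open, from the compounds shown here alone, is whether a saturated amine such as piperidin-4-yl, or a phenyl ring bearing a carboxylic acid, on this carbonyl carbon would move the number beyond the scatter. Also open, going by these compounds, is whether any change to the shared core outside this amide would do so.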